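From tert-Butoxycarbonyl to tert-Butylcarbamoyl: A Forecast

The compounds below may be only part of what the source reports. "The series", "measured", "known", "first", "only" and "open" are said of these compounds alone.

Compound 1, `CCN(CC)S(=O)(=O)c1ccc(S(=O)(=O)N2CCC[C@@H](C(=O)NC3CN(C(=O)OC(C)(C)C)C3)C2)cc1`, is the stronger of the two measured compounds in a functional assay on MIA PaCa-2 cells (Homo sapiens) for inhibition, read by MTT assay, with a stated time of 7 days; a lower number here means a stronger inhibitor, a higher number a weaker inhibitor: compound 1 gives 200 nM. Compound 2, `CCOC(=O)[C@@H]1CCCN(S(=O)(=O)c2ccc(S(=O)(=O)N(CC)C(C)C)cc2)C1`, lacks the amide-linked ring of compound 1 and carries an ethyl ester instead; in this assay compound 2 gives 1000 nM, a gap to compound 1 that lies beyond the usual scatter.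

The unmeasured compound 3, `CCN(CC)S(=O)(=O)c1ccc(S(=O)(=O)N2CCC[C@@H](C(=O)NC3CN(C(=O)NC(C)(C)C)C3)C2)cc1`, keeps the whole of compound 1 except for one change, ((tert-butyl)amino in place of tert-butoxy on a carbonyl carbon). For the measured compounds named here, no measured pair shows the effect of this particular change on the shared core, so there is nothing to lean on beyond the two values. The hydrogen-bond donor that enters and the acceptor that leaves sit far from the part of the molecule that separates compound 1 from compound 2.

The step from compound 1 to compound 3 is therefore expected to stay within the scatter, with no clear direction, as no change at the digits printed from compound 1 to compound 3 (within the scatter). Compound 3 is expected to give about 200 nM in this assay, between 70 nM and 600 nM.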

Compound 3, half-maximal inhibitory concentration: 3400 nM
Estimate against measurement, compound 3: 17-fold (1.23 log units) below; measured number above the stated range.
By their numbers in this assay, from the lowest: compound 1; then compound 2; then compound 3.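

In this assay, putting (tert-butyl)amino in place of tert-butoxy on a carbonyl carbon gives a 17-fold higher number from compound 1 to compound 3 (1.23 log units; beyond the scatter), so this carbonyl carbon, whose other neighbours are an amide-type nitrogen in a ring, is a place where a single change has a large effect on the number. Compounds 1 and 2 differ in more than one place and could say nothing about this position, whereas this step isolates it and shows that a large change can come from a swap that leaves the heavy-atom count, the absence of a ring and the absence of net charge as they were, exchanging only an oxygen for a nitrogen and a hydrogen-bond acceptor for a hydrogen-bond donor. Nothing in the data shown accounts for the size of this step.

Still open, going by these compounds, is whether the step follows the amide hydrogen that enters or the oxygen that leaves, a question that a (tert-butyl)(methyl)amino group on the same carbonyl carbon could help to separate. Also open, on these data alone, is how the number would respond to a smaller group there, such as methoxy, or to a free azetidine amine in place of the whole tert-butoxycarbonyl.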